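Notes on the benzyl analogue of compound 2

This account rests on a few compounds, and the source may have more. Where it says the series, first, only, none or still open, it means among the compounds named here.

Compound 1, `Cn1cc(CN2CCC[C@H](OCc3cc(Cl)cc(Cl)c3)[C@@H]2c2ccccc2)cn1`: in an assay on isolated protein for activation of cGMP-dependent protein kinase 1 (Homo sapiens), read by ADP-Glo, with stated times of 120 min and 40 min (a higher number here means that more compound is needed for the effect, a lower number that less compound is needed), compound 1 gives 110000 nM.
Compound 2, `Clc1cc(Cl)cc(CO[C@H]2CCCN(Cc3ccccn3)[C@H]2c2ccccc2)c1`: in this assay compound 2 gives only a limit, > 200000 nM.

Compound 2 stands at the limit of > 200000 nM in this assay, at which 1 of the 2 values shown sits; no number, only a ceiling, is known for it. Compound 3, `Clc1cc(Cl)cc(CO[C@H]2CCCN(Cc3ccccc3)[C@H]2c2ccccc2)c1`, differs from compound 2 by phenyl in place of pyridin-2-yl on a saturated chain carbon bound to an amine nitrogen in a ring. Going by the values given here, the single measured step, an at least 1.8-fold higher number from compound 1 to compound 2 (0.25 log units; that floor lies within the scatter), concerns the same position but a different pair of groups, and its floor lies within the scatter, so it sets no direction for the present change. Among the compounds with values here, no step from pyridin-2-yl to phenyl has been measured. The step is therefore expected to be a number no higher from compound 2 to compound 3 (the limit leaves the size open), none beyond the scatter, with a high chance that the assay again reports only a limit. Compound 3 is estimated at 200000 nM, with a range from 80000 nM to 500000 nM.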

Compound 3, half-maximal effective concentration: > 200000 nM
Compound 3: a limit, no number; the forecaster's own chance of this, stated with the estimate: 60%; the middle value sits exactly at the limit.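

With the ring nitrogen of pyridin-2-yl replaced by carbon in phenyl, this assay still yields no readable value at this place, and the step between the two limits cannot be read. Against compound 1, the only compound here with a number, the new group gives an at least 1.8-fold higher number from compound 1 to compound 3 (0.25 log units; that floor lies within the scatter), so this comparison sets no order between the groups. The limit now covers most of the short set: the limit of > 200000 nM in this assay, at which 2 of the 3 values shown sit.

Going by these compounds, whether any group on this saturated chain carbon can give a value clearly lower than that of compound 1 stays open, as do the true values of compound 2 and compound 3. Where a carboxylic acid, a primary amine or a longer chain at this place would fall in this assay is also open.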